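The source may report more compounds than this note shows. Statements on the series, on what has been measured and on what is new or still open speak of the compounds shown alone.

Measured so far in a functional assay on microsomes from liver (Rattus norvegicus, strain Wistar) for inhibition, with a stated time of 15 min; on this read-out higher numbers stand for weaker inhibition and lower numbers for stronger inhibition:
Compound 1 `COc1ccc(NC(=O)N2N=C(c3cc4ccccc4o3)CC2c2ccc(O)c(OC)c2)cc1` gives 29000000 nM
Compound 2 `COc1cc(NC(=O)N2N=C(c3cc4ccccc4o3)CC2c2ccc(O)c(OC)c2)ccc1O` gives 12000000 nM
Compound 3 `COc1cc(C2CC(c3cc4ccccc4o3)=NN2C(=O)Nc2ccc(O)c(O)c2)ccc1O` gives 11000000 nM

Compound 3 sits at the low end of these numbers, a place it shares: one gap (a 1.1-fold lower number from compound 2 to compound 3 (0.04 log units; within the scatter)) is within the scatter, while the other (a 2.6-fold lower number from compound 1 to compound 3 (0.42 log units; beyond the scatter)) is beyond it. Compound 4 `COc1cc(C2CC(c3cc4ccccc4o3)=NN2C(=O)Cl)ccc1O` differs from compound 3 in one place (chloro in place of (3,4-dihydroxyphenyl)amino on a carbonyl carbon), with chloro in place of (3,4-dihydroxyphenyl)amino on a carbonyl carbon. Going by the values given here, no measured step removes that whole group. The nearest evidence is a change of the group on the amide-type nitrogen, where 4-hydroxy-3-methoxyphenyl in place of 4-methoxyphenyl gave a modest shift (a 2.4-fold lower number from compound 1 to compound 2 (0.38 log units; beyond the scatter)). Compound 4 carries neither of these groups, so a modest drift back toward compound 1 (29000000 nM) is expected in this assay, although the direction remains uncertain. The expected step is a modest rise (a 2.0-fold higher number from compound 3 to compound 4 (0.30 log units; within the scatter)). For compound 4 the estimated value is 22000000 nM (expected range 8000000 nM to 60000000 nM).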

Compound 4, half-maximal inhibitory concentration: 147000000 nM
Beside the measured number, compound 4's estimate is 6.7-fold (0.82 log units) below it; the whole stated range lies below it.
By their numbers in this assay, from the lowest: compounds 3 and 2 (each within the scatter of the next); then compound 1; then compound 4.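

In this assay, the carbonyl carbon turns out to be far more sensitive to replacing the whole group than the earlier changes on the aromatic ring suggested: chloro in place of (3,4-dihydroxyphenyl)amino gave a 13-fold higher number from compound 3 to compound 4 (1.13 log units; beyond the scatter), and chloro in place of (4-hydroxy-3-methoxyphenyl)amino gave a 12-fold higher number from compound 2 to compound 4 (1.09 log units; beyond the scatter). Chloro in place of (4-methoxyphenyl)amino gave a smaller step, a 5.1-fold higher number from compound 1 to compound 4 (0.70 log units; beyond the scatter), so all three groups on that carbon, including the one with no free hydroxyl on its aromatic ring, give lower numbers than chloro. Nothing measured here accounts for the rise.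

The exchange removes the nitrogen, the aromatic ring and its substituents at once, and the compounds shown do not separate their shares. Where a plain phenylamino or a methylamino group on the carbonyl carbon would fall remains open.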